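Adding One Chloro Group to Compound 2

The source may hold more compounds than are shown below. What is called first, only, known or untested is meant among the compounds shown, and "the series" means these compounds.

In an ADME assay on L6 cells (Rattus norvegicus) for cytotoxicity, read by fluorescence and resazurin assay, with a stated time of 72 h (a lower number here means that less compound is tolerated, a higher number that more compound is tolerated), compound 1 (`Clc1ccc(C(c2c[nH]cc2-c2ccc(Cl)cc2-c2cccs2)n2ccnc2)c(Cl)c1`) gives 4930 nM and compound 2 (`O=[N+]([O-])c1ccc(-n2ccc(C(c3ccccc3)n3ccnc3)c2)cc1`) gives 60400 nM as the higher of these two numbers, well beyond the usual scatter. Compound 3 (`O=[N+]([O-])c1ccc(-n2ccc(C(c3ccc(Cl)cc3)n3ccnc3)c2)cc1`) differs from compound 2 by one change, phenyl to 4-chlorophenyl (chloro in place of hydrogen on an aromatic carbon), with chloro in place of hydrogen on an aromatic carbon. Among the compounds with values here, no measured pair shows this change alone. Compound 1 also carries chloro groups and stands at 4930 nM on the lower side, so a modest fall in the number is expected, possibly not much beyond the scatter. The step expected is a 1.9-fold lower number from compound 2 to compound 3 (0.28 log units; within the scatter) in this assay for this single change. Compound 3 is estimated at 32000 nM (range 13000 nM to 70000 nM).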

Compound 3, half-maximal cytotoxic concentration: 82400 nM
Compound 3: middle estimate off by 2.6-fold (0.41 log units), on the low side; the whole stated range lies below it.
By their numbers in this assay, from the lowest: compound 1; then compounds 2 and 3 (each within the scatter of the next).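

On the six-membered aromatic ring of compound 2, para to a large group, chloro in place of hydrogen gives a 1.4-fold higher number from compound 2 to compound 3 (0.13 log units; within the scatter) in this assay and so leaves the number indistinguishable from that of the parent. This single-change pair shows that, for these two compounds, this swap does not move the read-out beyond ordinary repeat variation. No independent measurement bears on this result. From the compounds shown here alone, whether an amine or a methoxy group at this same place would also leave the number unchanged stays open.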